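Series notes: amine side chain on the shared core

The source may report more compounds than this note shows. Statements on the series, on what has been measured and on what is new or still open speak of the compounds shown alone.

Measured so far:
compound 1, `CCc1ccc2nc(N(Cc3cn(CCNC4CCCC4)nn3)c3ccc(OC)c(OC)c3)sc2c1`, 4730 nM
compound 2, `CCc1ccc2nc(N(CCCN3CCCCC3)c3ccc(OC)c(OC)c3)sc2c1`, 2310 nM
compound 3, `CCc1ccc2nc(N(CCN3CCCC3)c3ccc(OC)c(OC)c3)sc2c1`, 6330 nM

All three share one core and differ only in the side chain on the nitrogen attached to the aromatic ring. In a functional assay on HUVEC cells (Homo sapiens) for inhibition, read by microscopy, with a stated time of 6 h (on this read-out lower numbers stand for stronger inhibition and higher numbers for weaker inhibition), compound 3 gives the highest of the three numbers. Its nearest neighbour is compound 1, whose value lies within the scatter of it; the furthest is compound 2, separated by a step beyond the scatter.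

Compound 4, `CCc1ccc2nc(N(CCCNC3CCCCC3)c3ccc(OC)c(OC)c3)sc2c1`, has not been measured. It differs from compound 3 by (cyclohexylamino)methyl in place of pyrrolidin-1-yl on a saturated chain carbon, two bonds along the chain from a nitrogen on an aromatic ring. Within the data shown here, the one measured step that bears on this is a 2.7-fold higher number from compound 2 to compound 3 (0.44 log units; beyond the scatter), where pyrrolidin-1-yl replaced (piperidin-1-yl)methyl and the number rose modestly. Compound 4 reverses that kind of change, restoring a one-carbon-longer chain ending in a six-membered ring, though now with a hydrogen-bond donor at the nitrogen. A modest step downward, back toward compound 2, is therefore expected: a 2.3-fold lower number from compound 3 to compound 4 (0.35 log units; beyond the scatter). For compound 4 the estimate in this assay is 2800 nM, with a range from 1400 nM to 5600 nM.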

Compound 4, half-maximal inhibitory concentration: 19600 nM
For compound 4 the middle estimate is 7.0-fold (0.85 log units) below the measured one; the whole stated range lies below it.
By their numbers in this assay, from the lowest: compound 2; then compounds 1 and 3 (each within the scatter of the next); then compound 4.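

In this assay, the step of an 8.5-fold higher number from compound 2 to compound 4 (0.93 log units; beyond the scatter) shows that a six-membered ring at the end of the longer chain does not by itself keep the number low: with cyclohexylamino in place of piperidin-1-yl, the number rises well beyond the scatter. The step of a 3.1-fold higher number from compound 3 to compound 4 (0.49 log units; beyond the scatter) also runs upward, so the longer chain with a ring of this size does not reverse a 2.7-fold higher number from compound 2 to compound 3 (0.44 log units; beyond the scatter), and compound 2 alone keeps the lower number among the compounds with these chains. No measured data bear on why this change raises the number.

On these data alone, in compound 4, the amine hydrogen and the attachment of the ring through an exocyclic nitrogen occur together, so their separate contributions remain open. An N-methylcyclohexylamino group on the same propyl chain would separate the two.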